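A few compounds are considered here, and "the series" means these few. Any claim that something is new, unique, unknown or untested is made for them only; others in the source may bear on it.

The measured compounds and their values:

Compound 1 `COc1ccccc1NC(=O)CCC(=O)OCCCCCCSc1ccc([N+](=O)[O-])c2nonc12` gives 280 nM in an assay on isolated protein for inhibition of glutathione S-transferase Mu 2 (Homo sapiens), with a stated time of 10 min; a higher number here means a weaker inhibitor, a lower number a stronger inhibitor.
Compound 2 `CN(C)CCNC(=O)CCC(=O)OCCCCCCSc1ccc([N+](=O)[O-])c2nonc12` gives 160 nM in this assay.

Compound 2 holds the lower of the two numbers, and its nearest neighbour is compound 1, separated by a 1.8-fold lower number from compound 1 to compound 2 (0.24 log units; within the scatter). Both compounds share the same core and differ only in the group on the amide-type nitrogen.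

Compound 3 `O=C(CCC(=O)N1CCOCC1)OCCCCCCSc1ccc([N+](=O)[O-])c2nonc12` takes the same core one change further: morpholin-4-yl in place of (2-(dimethylamino)ethyl)amino on a carbonyl carbon. Within the data shown here, the only measured step that bears on this part of the molecule is the one from compound 1 to compound 2, in which the amide substituent was exchanged and the number moved by a 1.8-fold lower number from compound 1 to compound 2 (0.24 log units; within the scatter), a shift that stays within the scatter. Among the measured compounds shown here, no measured pair shows a ring closed onto the amide nitrogen, so nothing indicates that this exchange should move the number beyond the scatter either.

Compound 3 is therefore expected to give 190 nM in this assay, with a range from 70 nM to 500 nM. The expected shift amounts to a 1.2-fold higher number from compound 2 to compound 3 (0.07 log units; within the scatter), which would be unremarkable.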

Compound 3, half-maximal inhibitory concentration: 170 nM
The estimate for compound 3 lay 1.1-fold (0.05 log units) above the measured number, within the range that was stated.
By their numbers in this assay, from the lowest: compounds 2, 3 and 1 (each within the scatter of the next).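

In this assay, the change from an open (2-(dimethylamino)ethyl)amino group to the morpholin-4-yl ring on the same carbonyl carbon is a 1.1-fold higher number from compound 2 to compound 3 (0.03 log units; within the scatter), and the change from (2-methoxyphenyl)amino to morpholin-4-yl is a 1.6-fold lower number from compound 1 to compound 3 (0.22 log units; within the scatter). Compound 3 is the first of these compounds without the amide hydrogen, and it also replaces the dimethylamino nitrogen of compound 2 with a ring oxygen, yet neither step leaves the scatter, so the amide hydrogen is not needed at this position for a number in this range. Three different groups on this carbonyl carbon, one aromatic, one an open chain and one a saturated ring, therefore cannot be told apart by this read-out, and no measurement is available that would explain this.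

The compounds shown leave open whether this position stays as undemanding with a free carboxylic acid or a primary amine on the carbonyl carbon, where the number might separate from the three values seen here. They also leave open how the number responds to a longer chain between the ester and the sulfur, since all three compounds share that part unchanged.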